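This account rests on a few compounds, and the source may have more. Where it says the series, first, only, none or still open, it means among the compounds named here.

Measured so far:
Compound 1, `O=C1Nc2ccc(S(=O)(=O)N3CCOCC3)cc2/C1=N/c1ccc(Br)cc1`: 11900 nM
Compound 2, `O=C1Nc2ccc(S(=O)(=O)N3CCOCC3)cc2/C1=N/c1ccc(O)cc1`: 10400 nM

Within the data shown here, in a functional assay on HepG2 cells (Homo sapiens) for cytotoxicity, read by sulforhodamine B assay, with a stated time of 24 h (on this read-out higher numbers stand for weaker inhibition and lower numbers for stronger inhibition), compound 2 gives 10400 nM, and compound 1 is the only comparison; the step of a 1.1-fold lower number from compound 1 to compound 2 (0.06 log units; within the scatter) separates them, so on this assay the two compounds are indistinguishable. Compound 3 is `O=C1Nc2ccc(S(=O)(=O)N3CCOCC3)cc2/C1=N/c1ccc(Cl)cc1`. It differs from compound 2 by chloro in place of hydroxy on an aromatic carbon. Among the measured compounds shown here, the one measured step that bears on this change is the halogen-to-hydroxy step, a 1.1-fold lower number from compound 1 to compound 2 (0.06 log units; within the scatter), which lay within the scatter. A halogen now replaces the hydroxy again, so no step beyond the scatter is expected. Compound 3 is therefore estimated at 11500 nM, between 6000 nM and 22000 nM, a change of a 1.1-fold higher number from compound 2 to compound 3 (0.04 log units; within the scatter).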

Compound 3, half-maximal inhibitory concentration: 11800 nM
Compound 3: middle estimate off by 1.0-fold (0.01 log units), on the low side, within the range that was stated.
By their numbers in this assay, from the lowest: compounds 2, 3 and 1 (each within the scatter of the next).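

Neither new step leaves the scatter in this assay, with a 1.1-fold higher number from compound 2 to compound 3 (0.05 log units; within the scatter) and a 1.0-fold lower number from compound 1 to compound 3 (0.00 log units; within the scatter). Chloro, bromo and hydroxy at this place on the aromatic ring therefore cannot be told apart, so the earlier single comparison now extends to a second halogen and to a direct hydroxy-to-chloro change. Nothing available explains why these groups read alike. Going by these compounds, whether an amine, a carboxylic acid or a longer chain at this place would move the number stays open, as does the effect of changes elsewhere on the shared core.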